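This account rests on a few compounds, and the source may have more. Where it says the series, first, only, none or still open, it means among the compounds named here.

In a functional assay on K562 cells (Homo sapiens) for inhibition, read by CCK-8 assay, with a stated time of 72 h (a higher number here means a weaker inhibitor, a lower number a stronger inhibitor), compound 1 `O=C(/C=C/c1cccnc1)NCCCc1ccc(S(=O)(=O)Nc2ccccc2)cc1` gives 4900 nM and compound 2 `Cc1ccc(C)c(NS(=O)(=O)c2cccc(CCCCCCNC(=O)/C=C/c3cccnc3)c2)c1` gives 0.84 nM as the lower of the two numbers, a gap well beyond the scatter. Compound 3 `O=C(/C=C/c1cccnc1)NCCCCCCc1cccc(S(=O)(=O)Nc2ccc(F)cc2)c1` differs from compound 2 in one place: 4-fluorophenyl in place of 2,5-dimethylphenyl on a sulfonamide nitrogen with 4-fluorophenyl in place of 2,5-dimethylphenyl on a sulfonamide nitrogen. Going by the values given here, no measured pair isolates this change, so only a small rise in the number is expected, with a 2.4-fold higher number from compound 2 to compound 3 (0.38 log units; beyond the scatter) as the estimated step in this assay for now. The estimate for compound 3 is 2 nM with a range of 0.4 nM to 12 nM expected for it.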

Compound 3, half-maximal inhibitory concentration: 0.93 nM
Compound 3: the middle estimate sits 2.2-fold (0.33 log units) above what was measured; the measured number falls inside the stated range.
By their numbers in this assay, from the lowest: compounds 2 and 3 (each within the scatter of the next); then compound 1.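

In this assay the change to 4-fluorophenyl in place of 2,5-dimethylphenyl on a sulfonamide nitrogen gives a 1.1-fold higher number from compound 2 to compound 3 (0.04 log units; within the scatter) and so stays within the scatter. This first single-place pair shows that this position accepts either aryl group with no readable change, so the two methyl groups are not needed to hold the number at the level of compound 2. Nothing at hand explains why the two groups read alike. Still open, on these data alone, is how a carboxylic acid or an amine on this ring would read, or a cyclohexyl ring in place of the aryl group.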